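Working notes: ring swap on the amine-bound chain carbon

The source may report more compounds than this note shows. Statements on the series, on what has been measured and on what is new or still open speak of the compounds shown alone.

The series shares one core, seen in compound 1 `COc1cc(N)c(Cl)cc1NC(=O)C1CCN(CC2CCC2)CC1` and compound 2 `COc1cc(N)c(Cl)cc1NC(=O)C1CCN(CC2CCCC2)CC1`, which differ only in the ring carried on a saturated chain carbon bound to an amine nitrogen in a ring. In a functional assay on the whole organism for antagonist activity, with Mus musculus as the target (a lower number here means that less compound is needed, a higher number that more compound is needed for the effect), compound 1 gives only a limit, > 10 mg/kg. In this assay compound 2 likewise gives only a limit, > 10 mg/kg. The step that the two limits leave unreadable from compound 1 to compound 2 therefore cannot be sized; both values sit at the limit of > 10 mg/kg in this assay, at which 2 of the 2 values shown sit, and compound 2 stands at that limit rather than at a number.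

Compound 3 `COc1cc(N)c(Cl)cc1NC(=O)C1CCN(Cc2ccc([N+](=O)[O-])cc2)CC1` is not yet measured. It differs from compound 2 by 4-nitrophenyl in place of cyclopentyl on a saturated chain carbon bound to an amine nitrogen in a ring. Among the compounds with values here, the only measured step bears on a ring at the same place but has no readable size, so it sets neither direction nor magnitude for the change to compound 3, and nothing else argues for a step beyond the scatter. Compound 3 is therefore expected near 15 mg/kg, within 4 mg/kg to 60 mg/kg, most likely reported again as a limit. The expected step is a step that the limit leaves unreadable from compound 2 to compound 3, none beyond the scatter.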

Compound 3, dose for half-maximal effect: > 4 mg/kg
Compound 3 was reported as a limit; the forecaster's own chance of this, stated with the estimate: 65%; the middle value is on the limit's open side.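

In this assay compound 3 gives only a limit, > 4 mg/kg. Within the data shown here, no step from compound 1 or compound 2 to compound 3 can be read. The compounds shown leave open how cyclobutyl, cyclopentyl and 4-nitrophenyl rank on a saturated chain carbon bound to an amine nitrogen in a ring, and whether any of them gives a number in this assay rather than a limit.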